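Swapping a silicon-bearing chain for a 1-phenylethyl group

The compounds below may be only part of what the source reports. "The series", "measured", "known", "first", "only" and "open" are said of these compounds alone.

Compound 1 `CCCCCNc1oc2c(C)ncc(CO)c2c1Nc1ccccn1`: 5810 nM in a functional assay on HEK293 cells for agonist activity at Toll-like receptor 8 (Homo sapiens), read by reporter gene assay; on this read-out lower numbers stand for an effect already at smaller amounts and higher numbers for an effect only at larger amounts of compound
Compound 2 `Cc1ncc(CO)c2c(Nc3cnccn3)c(NC(C)(C)C)oc12`: "not active" (no number reported) in this assay
Compound 3 `Cc1ncc(CO)c2c(Nc3ccccn3)c(NC[Si](C)(C)C)oc12`: 4990 nM in this assay

Compound 3 has the lowest of the two reported numbers, but its neighbour compound 1 lies within the scatter, as a 1.2-fold lower number from compound 1 to compound 3 (0.07 log units; within the scatter) shows. Compound 4 `Cc1ncc(CO)c2c(Nc3ccccn3)c(N[C@@H](C)c3ccccc3)oc12` is the next step: a group of 8 heavy atoms (8 carbon; one six-membered aromatic ring of carbon only) in place of a group of 5 heavy atoms (4 carbon, 1 silicon; no ring), on a nitrogen on an aromatic ring. For the measured compounds named here, the only measured step at this nitrogen, from compound 1 to compound 3, exchanged one chain for another and stayed within the scatter. Going by the values given here, no measured step brings an aromatic ring into this place, so the data give no firm direction. For compound 4 a step of a 1.7-fold lower number from compound 3 to compound 4 (0.22 log units; within the scatter) is expected, which means an estimated value of 3000 nM with a range from 700 nM to 13000 nM.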

Compound 4, half-maximal effective concentration: 4270 nM
Beside the measured number, compound 4's estimate is 1.4-fold (0.15 log units) below it, and the stated range covers the measured number.
By their numbers in this assay, from the lowest: compounds 4, 3 and 1 (each within the scatter of the next).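

Compound 4 is the only compound shown with an aromatic ring on this nitrogen, yet this assay gives a 1.2-fold lower number from compound 3 to compound 4 (0.07 log units; within the scatter) against the silicon-bearing chain and a 1.4-fold lower number from compound 1 to compound 4 (0.13 log units; within the scatter) against pentyl. At this nitrogen, then, the read-out does not separate 1-phenylethyl from either chain. No measured evidence explains this result.

Still open, from the compounds shown here alone, is whether the mirror-image form of 1-phenylethyl gives a similar number. A benzyl group or a longer chain such as octyl on this nitrogen might also move the number beyond the scatter.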